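The compounds below may be only part of what the source reports. "The series", "measured", "known", "first", "only" and "open" are said of these compounds alone.

In a functional assay, read by spectrophotometry, tested at 100 uM (a lower number here means a stronger inhibitor, a higher number a weaker inhibitor), three compounds built on one shared core have been measured. Compound 1 `O=C(/C=C/c1ccc(F)cc1)c1cccc(NC(=O)c2cc(-c3ccncc3)n[nH]2)c1` gives 56000 nM, compound 2 `O=C(/C=C/c1cccs1)c1cccc(NC(=O)c2cc(-c3ccncc3)n[nH]2)c1` gives 27600 nM, and compound 3 `CN(C)c1ccc(/C=C/C(=O)c2cccc(NC(=O)c3cc(-c4ccncc4)n[nH]3)c2)cc1` gives 41900 nM. Compound 3 thus stands within the scatter of both other compounds, and only compound 1 and compound 2 are separated by more than the scatter.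

Compound 4 `O=C(/C=C/c1ccco1)c1cccc(NC(=O)c2cc(-c3ccncc3)n[nH]2)c1` differs from compound 3 by one exchange: furan-2-yl in place of 4-(dimethylamino)phenyl on a double-bonded chain carbon bound to a double-bonded chain carbon. In words, furan-2-yl stands in place of 4-(dimethylamino)phenyl on a double-bonded chain carbon bound to a double-bonded chain carbon.

Going by the values given here, three measured steps bear on this exchange, since all of them change the group at this same place. The largest is modest, at a 2.0-fold lower number from compound 1 to compound 2 (0.31 log units; beyond the scatter). The other two stay within the scatter, at a 1.3-fold lower number from compound 1 to compound 3 (0.13 log units; within the scatter) and a 1.5-fold higher number from compound 2 to compound 3 (0.18 log units; within the scatter). The thiophen-2-yl of compound 2, at 27600 nM, is the closest measured counterpart to furan-2-yl.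

In this assay, the step is therefore expected to stay within the scatter, leaning slightly towards a lower number. The expected step is a 1.4-fold lower number from compound 3 to compound 4 (0.13 log units; within the scatter). For compound 4 the estimated value is 31000 nM, with an expected range of 16000 nM to 60000 nM.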

Compound 4, half-maximal inhibitory concentration: 41800 nM
Beside the measured number, compound 4's estimate is 1.3-fold (0.13 log units) below it; the range from low to high includes it.
By their numbers in this assay, from the lowest: compounds 2, 4, 3 and 1 (each within the scatter of the next, the first and the last beyond it).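

In this assay, the six-membered aromatic ring of carbon only in 4-(dimethylamino)phenyl gives way to the five-membered aromatic ring of furan-2-yl with no measurable effect (a 1.0-fold lower number from compound 3 to compound 4 (0.00 log units; within the scatter)), so at this place on a double-bonded chain carbon the number does not follow that exchange of ring. Furan-2-yl also stays within the scatter of the two remaining groups, both of thiophen-2-yl (a 1.5-fold higher number from compound 2 to compound 4 (0.18 log units; within the scatter)) and of 4-fluorophenyl (a 1.3-fold lower number from compound 1 to compound 4 (0.13 log units; within the scatter)), which leaves the step between compound 1 and compound 2 (a 2.0-fold lower number from compound 1 to compound 2 (0.31 log units; beyond the scatter)) as the only one beyond the scatter and shows that ring size alone does not sort these four compounds. No measurement is at hand that would explain any of these steps.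

The compounds shown leave open whether a group of another kind at this place, such as a piperidine ring, an open alkyl chain or a phenyl ring carrying a carboxylic acid, would take the number outside this narrow band. They also leave open what a saturated two-carbon chain would give in place of the double-bonded chain of 2-(furan-2-yl)ethenyl.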